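Sulfonyl aryl variation on a shared benzoxazole-free core

The source may hold more compounds than are shown below. What is called first, only, known or untested is meant among the compounds shown, and "the series" means these compounds.

Three compounds share one core and differ only in the group on the sulfonyl sulfur. Compound 1 `O=S(=O)(Nc1ccc2oc(-c3ccccc3)nc2c1)c1ccc(Cl)c(Cl)c1` carries a 3,4-dichlorophenyl there; in an assay on cells for inhibition of HSP60/HSP10 (Homo sapiens), with a stated time of 60 min (on this read-out higher numbers stand for weaker inhibition and lower numbers for stronger inhibition), compound 1 gives > 100000 nM, which is a limit of the assay and not a number. Compound 2 `Cc1ccccc1S(=O)(=O)Nc1ccc2oc(-c3ccccc3)nc2c1` carries a 2-methylphenyl and in this assay gives > 100000 nM, again a limit. Going by the values given here, compound 3 `O=S(=O)(Nc1ccc2oc(-c3ccccc3)nc2c1)c1cccc(O)c1` carries a 3-hydroxyphenyl and in this assay gives 76000 nM, the only number among the three. For compound 1 and compound 2 the values are limits (the limit of > 100000 nM in this assay, at which 2 of the 3 values shown sit).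

The step that the two limits leave unreadable from compound 1 to compound 2 cannot be read. The steps of an at least 1.3-fold lower number from compound 1 to compound 3 (0.11 log units; that floor lies within the scatter) and an at least 1.3-fold lower number from compound 2 to compound 3 (0.11 log units; that floor lies within the scatter) both have a floor that lies within the scatter, so no change beyond the scatter is shown.

Compound 4 `O=S(=O)(Nc1ccc2oc(-c3ccccc3)nc2c1)c1ccc(Cl)s1` is not yet measured. The change from compound 3 is 5-chlorothiophen-2-yl in place of 3-hydroxyphenyl on a sulfonyl sulfur. All three measured steps concern a change at the same sulfonyl sulfur and none shows a readable effect, so for compound 4 no step beyond the scatter is expected in this assay, and a limit is likely. For compound 4 the expected step is a 1.3-fold higher number from compound 3 to compound 4 (0.12 log units; within the scatter). Compound 4 is estimated at 100000 nM, between 30000 nM and 400000 nM.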

Compound 4, half-maximal inhibitory concentration: 70000 nM
Beside the measured number, compound 4's estimate is 1.4-fold (0.15 log units) above it; low and high end bracket the measured number.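

In this assay, going by these compounds alone, the change gives a 1.1-fold lower number from compound 3 to compound 4 (0.04 log units; within the scatter), the first step at the sulfonyl sulfur with a number at both ends, and it lies within the scatter. The 3-hydroxyphenyl, a six-membered carbon ring with a hydrogen-bond donor, thus gives way to 5-chlorothiophen-2-yl, a five-membered aromatic ring with no hydrogen-bond donor, with no readable change, so a donor on this group is not needed for a value below the limit in this pair. The other two new steps, an at least 1.4-fold lower number from compound 2 to compound 4 (0.15 log units; that floor lies within the scatter) and an at least 1.4-fold lower number from compound 1 to compound 4 (0.15 log units; that floor lies within the scatter), have floors within the scatter and stay floors only because compound 1 and compound 2 are limits and not numbers: the limit of > 100000 nM in this assay, at which 2 of the 4 values shown sit.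

The step between those two limits cannot be read, and no group shown at the sulfonyl sulfur moves the number beyond the scatter, so it remains open whether this position can change the read-out at all. Also open, going by these compounds, is what an amine or a carboxylic acid on the aromatic ring, or a longer alkyl chain in its place, would do in this assay.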